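The source may hold more compounds than are shown below. What is called first, only, known or untested is meant among the compounds shown, and "the series" means these compounds.

Measured so far in a functional assay on MOLT-4 cells (Homo sapiens) for antiproliferative activity, read by MTT assay, with a stated time of 72 h; a higher number here means a weaker inhibitor, a lower number a stronger inhibitor:

Compound 1 `O=C1NC(=O)/C(=C/C2=Cc3cc(Br)ccc3OC2)S1` gives 54700 nM.
Compound 2 `O=C1NC(=O)/C(=C/C2=Cc3cc(Br)ccc3OC2)N1` gives 77500 nM.
Compound 3 `CC1Oc2ccc(Br)cc2C=C1/C=C1\SC(=O)NC1=O` gives 64500 nM.

Compound 1 and compound 3 differ by one change, (methyl in place of hydrogen on a saturated ring carbon), and the step is a 1.2-fold higher number from compound 1 to compound 3 (0.07 log units; within the scatter). Compound 2 and compound 1 have different cores; that difference is not broken down here. Compound 4 `CC1Oc2ccc(Br)cc2C=C1/C=C1\NC(=O)NC1=O` is not yet measured; it stands to compound 2 as compound 3 stands to compound 1, by the same change, (methyl in place of hydrogen on a saturated ring carbon).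

For compound 4 in this assay the expected step from compound 2 is a 1.1-fold higher number from compound 2 to compound 4 (0.06 log units; within the scatter), resting on compound 1 and compound 3, where the same change gave a 1.2-fold higher number from compound 1 to compound 3 (0.07 log units; within the scatter). The estimate for compound 4 is therefore 88000 nM, with a range of 45000 nM to 170000 nM expected.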

Compound 4, half-maximal inhibitory concentration: 24800 nM
The estimate for compound 4 lay 3.5-fold (0.55 log units) above the measured number, outside the stated range (below it).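

In this assay methyl in place of hydrogen on a saturated ring carbon gives a 3.1-fold lower number from compound 2 to compound 4 (0.49 log units; beyond the scatter) on the core of compound 2. The change therefore cannot be carried as one fixed step between these two cores, as the two steps differ: the same change on two cores in this assay, a 1.2-fold higher number (0.07 log units; within the scatter) from compound 1 to compound 3 and a 3.1-fold lower number (0.49 log units; beyond the scatter) from compound 2 to compound 4, 3.7-fold (0.57 log units) apart, beyond the scatter of two such steps. This shows that the size of the step depends on the core across these four compounds, but with one pair per core it does not show why, or what the change would do on any other core.

Still open, as far as these compounds go, is whether ethyl or a longer chain on the same saturated ring carbon would go further than methyl on the core of compound 2. From the compounds shown here alone, an amine or a carboxylic acid at that carbon is equally open.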